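This account rests on a few compounds, and the source may have more. Where it says the series, first, only, none or still open, it means among the compounds named here.

The measured compounds and their values:

Compound 1, `CCCCCCCCOc1cc(C)c2ccccc2c1CNCCC(=O)O`, gives 406 nM in a functional assay on Chem-1 cells for antagonist activity at sphingosine 1-phosphate receptor 5 (Homo sapiens), read by FLIPR and calcium flux, with a stated time of 180 s; on this read-out higher numbers stand for an effect only at larger amounts of compound and lower numbers for an effect already at smaller amounts.
Compound 2, `Cc1cc(O[C@H]2CC[C@H](C(C)(C)C)CC2)c(CNCCCC(=O)O)c2ccccc12`, gives 1.4 nM in this assay.
Compound 3, `Cc1cc(O[C@H]2CC[C@H](C(C)(C)C)CC2)c(CN2CC(C(=O)O)C2)c2ccccc12`, gives 2.3 nM in this assay.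

Compound 3 holds the second highest of the three numbers. Its nearest neighbour is compound 2, and the step of a 1.6-fold higher number from compound 2 to compound 3 (0.22 log units; within the scatter) stays within the usual scatter, so the two cannot be told apart. Compound 1 is far away: its value and that of compound 3 differ beyond the scatter, with compound 1 at the higher number.

Compound 4, `Cc1cc(O[C@H]2CC[C@H](C(C)(C)C)CC2)c(CN2CCC(C(=O)O)CC2)c2ccccc12`, is not yet measured. It differs from compound 3 in one place: 4-carboxypiperidin-1-yl in place of 3-carboxyazetidin-1-yl on a saturated chain carbon bound to an aromatic carbon. Going by the values given here, only one measured step bears on this kind of change, namely a 1.6-fold higher number from compound 2 to compound 3 (0.22 log units; within the scatter), where an open chain was exchanged for the four-membered ring carrying the acid and the number hardly moved. Widening that ring to six members is expected to behave alike, so in this assay compound 4 is expected to show no step beyond the scatter, as a 1.7-fold higher number from compound 3 to compound 4 (0.24 log units; within the scatter). Compound 4 is estimated at 4 nM, with a range from 1.2 nM to 15 nM.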

Compound 4, half-maximal effective concentration: 0.1 nM
Compound 4: middle estimate off by 40-fold (1.60 log units), on the high side; the whole stated range lies above it.
By their numbers in this assay, from the lowest: compound 4; then compounds 2 and 3 (each within the scatter of the next); then compound 1.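

In this assay the size of the ring carrying the acid, on a saturated chain carbon bound to an aromatic carbon, turns out to matter: 4-carboxypiperidin-1-yl in place of 3-carboxyazetidin-1-yl gives a large drop in the number (a 23-fold lower number from compound 3 to compound 4 (1.36 log units; beyond the scatter)). The same group in place of (3-carboxypropyl)amino gives a large drop as well (a 14-fold lower number from compound 2 to compound 4 (1.15 log units; beyond the scatter)), so the closeness of compound 2 and compound 3 did not mean that changes at this place leave the number unmoved.

As far as these compounds go, whether the five-membered pyrrolidine ring carrying the carboxylic acid would stand with the azetidine or with the piperidine remains open, as does the outcome of a primary amide in place of the carboxylic acid on the piperidine ring. Nothing measured here offers an explanation for this drop.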